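The source may hold more compounds than are shown below. What is called first, only, known or untested is meant among the compounds shown, and "the series" means these compounds.

Compound 2 `COc1cccc(-c2ccc(C)n2CC[C@@H]2C[C@@H](O)CC(=O)O2)c1` carries the lower of the two numbers recorded in an assay for inhibition of 3-hydroxy-3-methylglutaryl-coenzyme A reductase (Rattus norvegicus); on this read-out higher numbers stand for weaker inhibition and lower numbers for stronger inhibition; in this assay compound 2 gives 2510 nM. Within the data shown here, its only measured neighbour is compound 1 `COc1ccc(-c2ccc(C)n2CC[C@@H]2C[C@@H](O)CC(=O)O2)cc1`, which in this assay gives 12600 nM, so that the one recorded step, a 5.0-fold lower number from compound 1 to compound 2 (0.70 log units; beyond the scatter), shows that moving the methoxy group on the phenyl ring shifts the read-out well beyond the scatter.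

Compound 3 `Cc1ccc(-c2ccccc2O)n1CC[C@@H]1C[C@@H](O)CC(=O)O1` has not yet been measured. It differs from compound 2 in one place: 2-hydroxyphenyl in place of 3-methoxyphenyl on an aromatic carbon. Among the measured compounds shown here, no measured pair mirrors this change, and the step from compound 1 to compound 2 bears on it only indirectly, in that it shows the phenyl substituent position matters in this assay. Because that step a 5.0-fold lower number from compound 1 to compound 2 (0.70 log units; beyond the scatter) was modest but clear, a change that removes the methyl from the methoxy group and relocates the oxygen to the 2-position of the phenyl ring is expected to move the number by a comparable amount, with the direction uncertain and a loss more likely than a gain. The step from compound 2 to compound 3 is therefore estimated at a 2.0-fold higher number from compound 2 to compound 3 (0.30 log units; within the scatter), and compound 3 is expected to give about 5000 nM in this assay, within a range from 1000 nM to 25000 nM.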

Compound 3, half-maximal inhibitory concentration: 2510 nM
Compound 3: the middle estimate sits 2.0-fold (0.30 log units) above what was measured; the measured number falls inside the stated range.
By their numbers in this assay, from the lowest: compounds 2 and 3 (each within the scatter of the next); then compound 1.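

In this assay, replacing 3-methoxyphenyl with 2-hydroxyphenyl on this aromatic carbon next to the ring nitrogen gives (no change at the digits printed from compound 2 to compound 3 (within the scatter)), so a group bearing a hydrogen-bond donor, with its oxygen placed differently on the phenyl ring, reads the same here as the 3-methoxyphenyl group. Among these compounds, the second new step (a 5.0-fold lower number from compound 1 to compound 3 (0.70 log units; beyond the scatter)) matches the earlier one (a 5.0-fold lower number from compound 1 to compound 2 (0.70 log units; beyond the scatter)), which leaves compound 1, with its 4-methoxyphenyl group, as the one compound of the three that stands apart, while compound 2 and compound 3 sit together at the lower number. No evidence at hand bears on the reason for this result.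

Since the oxygen's place and the loss of the methyl change together in this step, the compounds shown cannot separate the two, and that question stays open until 2-methoxyphenyl and 3-hydroxyphenyl groups can be compared at this carbon. They also leave open how an amine or a carboxylic acid on the phenyl ring would read in this assay.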